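The compounds below may be only part of what the source reports. "The series", "measured", "known", "first", "only" and "open" are said of these compounds alone.

Working notes on the series in a functional assay on PC-3 cells (Homo sapiens) for cytotoxicity, read by WST assay, with a stated time of 48 h; on this read-out lower numbers stand for stronger inhibition and higher numbers for weaker inhibition.

Compound 1, `COc1ccc2c(/C=C(\C#N)C(=O)c3c[nH]c4cc(OC)ccc34)c[nH]c2c1`, carries methoxy on each of its fused ring systems. In this assay compound 1 gives 27000 nM.

Compound 2, `N#C/C(=C\c1c[nH]c2ccccc12)C(=O)c1c[nH]c2ccccc12`, is the parent without methoxy. For compound 2 this assay reports only a limit, > 50000 nM, and not a number. On the numbers shown, compound 2 therefore stands at the weak end: it sits at the limit of > 50000 nM in this assay, at which 1 of the 2 values shown sits, while compound 1 has a measured value.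

Compound 3, `COc1ccc2c(C(=O)/C(C#N)=C/c3c[nH]c4ccccc34)c[nH]c2c1`, follows from compound 2 by a single change: methoxy in place of hydrogen on an aromatic carbon. Among the compounds with values here, no measured step between two compounds is available, so the size of this change can only be judged from the distance between compound 1 and the limit of compound 2. A single methoxy is expected to move compound 3 in the direction of stronger inhibition, but by a step that may not clear the scatter: from compound 2 to compound 3 the expected change is an at least 1.2-fold lower number from compound 2 to compound 3 (0.09 log units; that floor lies within the scatter). For compound 3 the estimate in this assay is 40000 nM, with a range from 18000 nM to 90000 nM.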

Compound 3, half-maximal inhibitory concentration: 12000 nM
Compound 3: the middle estimate sits 3.3-fold (0.52 log units) above what was measured; measured number below the stated range.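

In this assay, methoxy in place of hydrogen on an aromatic carbon of a six-membered aromatic ring of carbon only now has a readable size: an at least 4.1-fold lower number from compound 2 to compound 3 (0.61 log units; beyond the scatter). The second methoxy of compound 1 does not add to this gain, since the reverse exchange at that other place gives a 2.3-fold lower number from compound 1 to compound 3 (0.35 log units; beyond the scatter), so in this pair the same group is favourable at one place and unfavourable at the other. The first step can be read only as a floor because compound 2 stands at a limit of the assay, not at a number: the limit of > 50000 nM in this assay, at which 1 of the 3 values shown sits.

From the compounds shown here alone, whether the gain belongs to methoxy itself stays open, since a hydroxy group, a fluorine atom or a longer alkoxy chain at the same place could give a smaller or a larger step. Also open, going by these compounds, is how a single methoxy would read at the other place on its own, and whether an amide or a carboxylic acid in place of the nitrile would keep the number seen for compound 3.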